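The source may report more compounds than this note shows. Statements on the series, on what has been measured and on what is new or still open speak of the compounds shown alone.

Three compounds have already been measured in an ADME assay on BJ cells (Homo sapiens) for cytotoxicity, with a stated time of 72 h (on this read-out higher numbers stand for an effect only at larger amounts of compound and lower numbers for an effect already at smaller amounts), and each of them returned only a limit of the assay rather than a number:

compound 1 `COc1cc(Cl)c(C(=O)Nc2cccc(-c3nc4ccccc4s3)c2)cc1[N+](=O)[O-]`: > 25000 nM, a limit.
compound 2 `Cc1ccc(-c2nc3ccccc3s2)cc1NC(=O)c1cc([N+](=O)[O-])c(N2CCC(C(=O)O)CC2)cc1Cl`: > 25000 nM, a limit.
compound 3 `O=C(Nc1nc2ccc(Cl)cc2s1)c1cc([N+](=O)[O-])ccc1Cl`: > 27000 nM, a limit.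

Compound 1 therefore stands at the limit that two of the three compounds share (the limit of > 25000 nM in this assay, at which 2 of the 3 values shown sit), while compound 3 sits at a slightly different limit (the limit of > 27000 nM in this assay, at which 1 of the 3 values shown sits). Among the compounds with values here, all three results are limits; no difference between them can be read, and no pair shows a step beyond the scatter.

Compound 4 `O=C(O)COc1cc(Cl)c(C(=O)Nc2cccc(-c3nc4ccccc4s3)c2)cc1[N+](=O)[O-]` is not yet measured. It differs from compound 1 in one place: carboxy in place of hydrogen on a saturated chain carbon bound to an oxygen on an aromatic ring. The carboxy group enters on the saturated chain carbon bound to an oxygen on the aromatic ring, so that the methoxy of compound 1 becomes a carboxymethoxy group. Within the data shown here, with every measured compound sitting at a limit in this assay, there is no measured step that would point in either direction, and the step that the limit leaves unreadable from compound 1 to compound 4 is expected to be none beyond the scatter. Compound 4 is expected to give 30000 nM in this assay, with a range from 15000 nM to 60000 nM, and most likely again only a limit.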

Compound 4, half-maximal effective concentration: > 25000 nM
Compound 4 gave a limit, no number (the forecaster's own chance of this, stated with the estimate: 85%); the middle value does not contradict the limit.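

From the compounds shown here alone, compound 1 and compound 4 both returned only a limit rather than a number, so no step can be read between them, and the effect of replacing the methoxy with carboxymethoxy remains unknown. The compounds shown leave open at what concentration, if any, each of the four would produce an effect on these cells.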